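This account rests on a few compounds, and the source may have more. Where it says the series, first, only, none or still open, it means among the compounds named here.

Measured so far: compound 1 `CCN(CC)CCCn1c(=O)c(=Cc2ccc(F)c(F)c2)s/c1=C1\C(=O)Nc2cc(F)ccc21` gives 2900 nM in a functional assay on MDA-MB-231 cells (Homo sapiens) for inhibition, read by MTT assay, with a stated time of 72 h; on this read-out higher numbers stand for weaker inhibition and lower numbers for stronger inhibition; compound 2 `CN(C)CCn1c(=O)c(=Cc2ccc(F)cc2F)s/c1=C1\C(=O)Nc2cc(F)ccc21` gives 8440 nM; compound 3 `COc1ccc(C=c2s/c(=C3\C(=O)Nc4cc(F)ccc43)n(CCN(C)C)c2=O)cc1` gives 2090 nM.

Compound 2 stands at the highest number of the three; the nearest is compound 1, the furthest compound 3. Compound 4 `CCN(CC)CCCn1c(=O)c(=Cc2ccc(F)cc2F)s/c1=C1\C(=O)Nc2cc(F)ccc21` keeps the aryl group of compound 2 and changes only the chain: (diethylamino)methyl in place of dimethylamino on a saturated chain carbon, two bonds along the chain from an aromatic nitrogen. Among the compounds with values here, no measured step concerns this chain alone. Within the data shown here, the only single-place step, a 4.0-fold lower number from compound 2 to compound 3 (0.61 log units; beyond the scatter), touches the aryl group instead. Compound 1 and compound 2 differ in both chain and aryl group, so their values show only that the longer diethylamino chain sits with the lower number. A modest step toward a lower number is therefore expected for compound 4, a 2.0-fold lower number from compound 2 to compound 4 (0.30 log units; within the scatter), with an estimate of 4200 nM and a range from 1500 nM to 11000 nM.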

Compound 4, half-maximal inhibitory concentration: 2100 nM
Compound 4: the middle estimate sits 2.0-fold (0.30 log units) above what was measured, and the stated range covers the measured number.
By their numbers in this assay, from the lowest: compounds 3, 4 and 1 (each within the scatter of the next); then compound 2.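

With the 2,4-difluorophenyl group held fixed, the chain change alone, 2-(dimethylamino)ethyl to 3-(diethylamino)propyl, gives a 4.0-fold lower number from compound 2 to compound 4 (0.60 log units; beyond the scatter) in this assay. With the 3-(diethylamino)propyl chain held fixed, moving between the difluorophenyl patterns gives a 1.4-fold lower number from compound 1 to compound 4 (0.14 log units; within the scatter), so this pair does not separate 2,4-difluorophenyl from 3,4-difluorophenyl. No evidence is available on what lies behind either step.

Chain length and the ethyl groups on the nitrogen change together in this step, and the two cannot be told apart. As far as these compounds go, whether a morpholine or piperidine at the chain end would give a similar number also stays open.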